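The source may hold more compounds than are shown below. What is called first, only, known or untested is meant among the compounds shown, and "the series" means these compounds.

These notes follow the series in a functional assay on NCI-H460 cells (Homo sapiens) for cytotoxicity; on this read-out lower numbers stand for stronger inhibition and higher numbers for weaker inhibition. The unsubstituted compound 1 `O=C(CCCCCCC(=O)Nc1nc2ccccc2s1)NO` gives 5.71 ug/mL, compound 2 `Cc1ccc2nc(NC(=O)CCCCCCC(=O)NO)sc2c1` gives 0.84 ug/mL, and compound 3 `O=C(CCCCCCC(=O)Nc1nc2ccc([N+](=O)[O-])cc2s1)NO` gives 1.9 ug/mL. Compound 3 therefore holds the second highest of the three numbers, between the other two and clear of both beyond the scatter.

The next compound, compound 4 `CCOc1ccc2nc(NC(=O)CCCCCCC(=O)NO)sc2c1`, has ethoxy in place of nitro on an aromatic carbon. Going by the values given here, no measured step involves ethoxy, so the evidence is indirect. Among the compounds with values here, three steps bear on the change. Adding a group to the core of compound 1 gave a 6.8-fold lower number from compound 1 to compound 2 (0.83 log units; beyond the scatter) with methyl and a 3.0-fold lower number from compound 1 to compound 3 (0.48 log units; beyond the scatter) with nitro. Exchanging these two groups gave a 2.3-fold higher number from compound 2 to compound 3 (0.35 log units; beyond the scatter). All three steps are modest, and both substituted compounds lie below compound 1, though two compounds make a thin basis for any pattern. The exchange closest to the new one, a 2.3-fold higher number from compound 2 to compound 3 (0.35 log units; beyond the scatter), only just clears the scatter, so a large move is not expected in this assay, and the direction is poorly defined. A slight drop, staying within the scatter, is expected: a 1.3-fold lower number from compound 3 to compound 4 (0.10 log units; within the scatter). Compound 4 is estimated at 1.5 ug/mL, with an expected range from 0.5 ug/mL to 4.5 ug/mL.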

Compound 4, half-maximal inhibitory concentration: 6.58 ug/mL
Estimate against measurement, compound 4: 4.4-fold (0.64 log units) below; measured number above the stated range.
By their numbers in this assay, from the lowest: compound 2; then compound 3; then compounds 1 and 4 (each within the scatter of the next).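

In this assay, this position no longer reads as one where any added group lowers the number: a 1.2-fold higher number from compound 1 to compound 4 (0.06 log units; within the scatter), so the ethoxy compound stays level with the unsubstituted one, while methyl and nitro both sit clearly lower. The identity of the group on this aromatic carbon therefore matters well beyond the scatter, even among groups of similar size by heavy-atom count, with a 3.5-fold higher number from compound 3 to compound 4 (0.54 log units; beyond the scatter) for the exchange of nitro and a 7.8-fold higher number from compound 2 to compound 4 (0.89 log units; beyond the scatter) for the exchange of methyl. The two alkyl-bearing groups, methyl and ethoxy, also part clearly, so having carbon in the substituent does not by itself keep the low number seen with compound 2, and nothing available bears on why ethoxy behaves this way.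

On these data alone, it remains open whether the loss follows the ether oxygen or the greater length of the group, a question that methoxy and ethyl on the same carbon would help to separate. Also open is how a hydroxy group or an amine would read here, since the three substituents shown give too few points to rank groups at this position by any shared feature.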